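A few compounds are considered here, and "the series" means these few. Any claim that something is new, unique, unknown or untested is made for them only; others in the source may bear on it.

Measured compounds:
compound 1, `O=C(/C=C/c1ccc(O)cc1)Nc1cc2c(Nc3ccc(Cl)c(Cl)c3)ncnc2s1`: 34300 nM
compound 2, `N#Cc1cccc(Nc2ncnc3cc(NC(=O)/C=C/c4ccccc4)sc23)c1`: 17200 nM

Both numbers come from a functional assay on A549 cells (Homo sapiens) for antiproliferative activity, read by MTT assay, with a stated time of 48 h; on this read-out higher numbers stand for weaker inhibition and lower numbers for stronger inhibition. In this assay compound 1 gives 34300 nM and compound 2 gives 17200 nM; the two values lie within the usual scatter of each other, so neither can be placed above the other on the numbers shown. Among the compounds with values here, no two measured compounds differ in a single place, so no step between measured compounds is available to lean on.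

Compound 3, `O=C(/C=C/c1ccccc1)Nc1cc2c(Nc3ccc(Cl)c(Cl)c3)ncnc2s1`, is compound 1 with the change (hydrogen in place of hydroxy on an aromatic carbon). Compound 2 also carries the 2-phenylethenyl group, but its aniline differs from that of compound 1 as well, so its value cannot be read as the effect of the hydroxy removal alone. With nothing in the measured pair to indicate a direction, the step from compound 1 to compound 3 is expected to be small, not beyond the scatter, and the estimate a 1.4-fold lower number from compound 1 to compound 3 (0.14 log units; within the scatter) reflects that. Compound 3 is accordingly estimated at 25000 nM, with a range of 8000 nM to 80000 nM.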

Compound 3, half-maximal inhibitory concentration: 7600 nM
Beside the measured number, compound 3's estimate is 3.3-fold (0.52 log units) above it; the measured number lies below the stated range.
By their numbers in this assay, from the lowest: compound 3; then compounds 2 and 1 (each within the scatter of the next).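

In this assay, within the data shown here, this is the first change that can be read at a single place: with hydrogen in place of hydroxy on the aromatic carbon para to a large group, the 4-hydroxyphenyl to phenyl change gives a 4.5-fold lower number from compound 1 to compound 3 (0.65 log units; beyond the scatter). The earlier pair could not show this, since compound 1 and compound 2 differ in more than one place and their values lie within the scatter, whereas this step shows that the position is not indifferent to what it carries, with the unsubstituted phenyl giving the lower number of the two. This holds for one pair on one core only, and no measurement at hand bears on why the number moves in this direction.

Open, as far as these compounds go, is where a methoxy group, an amine or a carboxylic acid on the same carbon would fall relative to compound 1 and compound 3, and whether hydroxy on another carbon of that ring would give the same result. Also open, from the compounds shown here alone, is whether the step carries over to the aniline and core of compound 2, since one step fixes no trend.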